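From Dimethylcarbamoyl to Methanesulfonamido on the Shared Core

A few compounds are considered here, and "the series" means these few. Any claim that something is new, unique, unknown or untested is made for them only; others in the source may bear on it.

Measured in a functional assay for inhibition, with Homo sapiens as the target (on this read-out higher numbers stand for weaker inhibition and lower numbers for stronger inhibition), so far:
Compound 1 `c1ccc(C(CC2CCCCC2)Nc2nc3ccccc3o2)cc1` gives 340 nM; 8 nM; 6 nM (3 entries)
Compound 2 `Cc1ccc2oc(N[C@@H](CC3CCCCC3)c3ccccn3)nc2c1` gives 1 nM
Compound 3 `CN(C)C(=O)c1ccc2oc(NC(CC3CCCCC3)c3ccccc3)nc2c1` gives 170 nM

Among the measured compounds shown here, compound 3 stands at the high end of the single numbers in this assay and is the weaker inhibitor of the two compounds that have one. Compound 3 reads 170 nM, whereas compound 2 reads 1 nM. Compound 1 offers no single number for comparison, since its repeat entries lie far apart (the several entries of compound 1 in this assay, 340 nM; 8 nM; 6 nM (3 entries)).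

The next compound, compound 4 `CS(=O)(=O)Nc1ccc2oc(NC(CC3CCCCC3)c3ccccc3)nc2c1`, carries methanesulfonamido in place of dimethylcarbamoyl on an aromatic carbon. For the measured compounds named here, no measured pair in this small set shows what such an exchange does, and the expectation is correspondingly loose. No change beyond the scatter is expected, in either direction. The expected step of a 1.4-fold lower number from compound 3 to compound 4 (0.15 log units; within the scatter) is accordingly small, although its uncertainty is wide. For compound 4 the estimated value is 120 nM, with an expected range from 15 nM to 800 nM.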

Compound 4, half-maximal inhibitory concentration: 160 nM
Compound 4: the middle estimate sits 1.3-fold (0.12 log units) below what was measured, within the range that was stated.
By their numbers in this assay, from the lowest: compound 2; then compounds 4 and 3 (each within the scatter of the next).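

In this assay, among the compounds shown here, methanesulfonamido in place of dimethylcarbamoyl on an aromatic carbon gives a 1.1-fold lower number from compound 3 to compound 4 (0.03 log units; within the scatter), the first step in this set that isolates this position. The two groups have the same number of heavy atoms, but methanesulfonamido brings a hydrogen-bond donor that dimethylcarbamoyl lacks, and this exchange leaves the read-out within the scatter. At this position, then, the assay does not tell the two groups apart.

Also open, from the compounds shown here alone, is how an amine or a carboxylic acid on this aromatic carbon would read. Whether either group shifts the number relative to compound 1, which carries neither, cannot be read: the several entries of compound 1 in this assay, 340 nM; 8 nM; 6 nM (3 entries)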